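A Benzyl Swap at the Assay Limit

The source may report more compounds than this note shows. Statements on the series, on what has been measured and on what is new or still open speak of the compounds shown alone.

Compound 1 `O=S(=O)(c1ccc(-c2ccc3ncnc(Nc4ccc(OCc5cccc(F)c5)c(Cl)c4)c3c2)cc1)N1CCCCC1`, compound 2 `O=S(=O)(c1cccc(-c2ccc3ncnc(Nc4ccc(OCc5cccc(F)c5)c(Cl)c4)c3c2)c1)N1CCCC1` and compound 3 `O=S(=O)(c1ccc(-c2ccc3ncnc(Nc4ccc(OCc5cccc(Br)c5)c(Cl)c4)c3c2)cc1)N1CCOCC1` have all been measured in an ADME assay on HepG2 cells (Homo sapiens) for cytotoxicity, read by MTT assay, with a stated time of 48 h; on this read-out higher numbers stand for weaker inhibition and lower numbers for stronger inhibition. Compound 1 gives > 15000 nM, which is a limit of the assay and not a number. Compound 2 gives > 15000 nM, again a limit. Compound 3 gives > 15000 nM, also only a limit. Compound 3 therefore has no numerical position in the series, which so far offers only (the limit of > 15000 nM in this assay, at which 3 of the 3 values shown sit).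

Compound 4 `O=S(=O)(c1ccc(-c2ccc3ncnc(Nc4ccc(OCc5ccc(C(F)(F)F)c(F)c5)c(Cl)c4)c3c2)cc1)N1CCOCC1` differs from compound 3 in one place, on a saturated chain carbon bound to an oxygen on an aromatic ring: 3-fluoro-4-(trifluoromethyl)phenyl in place of 3-bromophenyl on a saturated chain carbon bound to an oxygen on an aromatic ring. Cut one bond further out, the same change reads 3-bromobenzyl to 3-fluoro-4-(trifluoromethyl)benzyl.

For the measured compounds named here, no measured pair shows what such a change does in this assay. With compound 3 reported at > 15000 nM, a limit, no step beyond the usual scatter is expected, and no direction can be argued from the data. The expected change is a step that the limit leaves unreadable from compound 3 to compound 4. The most likely outcome is another limit rather than a number. As an estimate, compound 4 is expected to read about 20000 nM, within an expected range of 9000 nM to 40000 nM.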

Compound 4, half-maximal inhibitory concentration: > 15000 nM
Compound 4 gave a limit, no number; the forecaster's own chance of this, stated with the estimate: 75%; the middle value is on the limit's open side.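

In this assay compound 4 gives > 15000 nM as a limit and not a number. Compound 3 also sits at a limit, so no step can be read between compound 3 and compound 4. The compounds shown leave open what the change from 3-bromobenzyl to 3-fluoro-4-(trifluoromethyl)benzyl does to cytotoxicity, since the series offers only this: the limit of > 15000 nM in this assay, at which 4 of the 4 values shown sit.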